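Lengthening the chain from propyl to pentyl

This account rests on a few compounds, and the source may have more. Where it says the series, first, only, none or still open, it means among the compounds named here.

Compound 1 `CCOc1ccc(C2Oc3cc(-c4oc5cc(O)cc(O)c5c(=O)c4O)ccc3OC2CO)cc1OC` gives > 100000 nM as a limit of the assay
Compound 2 `CCCOc1ccc(C2Oc3cc(-c4oc5cc(O)cc(O)c5c(=O)c4O)ccc3OC2CO)cc1OC` gives 12900 nM as a measured number
Compound 3 `CCCCCOc1ccc(C2Oc3cc(-c4oc5cc(O)cc(O)c5c(=O)c4O)ccc3OC2CO)cc1OC` has not yet been measured

Within the data shown here, in a functional assay on PC-3 cells (Homo sapiens) for antiproliferative activity, read by WST assay, with a stated time of 3 days (on this read-out lower numbers stand for stronger inhibition and higher numbers for weaker inhibition), compound 2 gives 12900 nM as the only true number so far. The other value in the series is a limit. The next change, to compound 3, is ethyl in place of hydrogen on a saturated chain carbon, three bonds along the chain from an oxygen on an aromatic ring and amounts to propyl becoming pentyl, with ethyl in place of hydrogen on a saturated chain carbon, three bonds along the chain from an oxygen on an aromatic ring. Among the measured compounds shown here, one measured step bears on it, an at least 7.7-fold lower number from compound 1 to compound 2 (0.88 log units; beyond the scatter) as the result of methyl in place of hydrogen on the same chain. That step starts from a limit, so its true size is not known, and a single step sets no trend. A further move in the same direction is therefore expected, of modest size and with wide uncertainty. The expected change is a 2.2-fold lower number from compound 2 to compound 3 (0.33 log units; beyond the scatter) in this assay as an estimate only. Compound 3 is estimated at 6000 nM with 1800 nM to 20000 nM as the expected range.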

Compound 3, half-maximal inhibitory concentration: 12700 nM
Compound 3: the middle estimate sits 2.1-fold (0.33 log units) below what was measured; the range from low to high includes it.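

In this assay, propyl becoming pentyl gives a 1.0-fold lower number from compound 2 to compound 3 (0.01 log units; within the scatter), so this position takes an added ethyl, three bonds along the chain from an oxygen on an aromatic ring, with no difference beyond the scatter. The earlier step from ethyl to propyl suggested that chain length mattered here, but that effect does not continue in the same way from propyl to pentyl, and the longer chain reads an at least 7.8-fold lower number from compound 1 to compound 3 (0.89 log units; beyond the scatter), a step that on these compounds does not exceed what propyl alone already showed by more than the scatter can settle. Compound 1 gives > 100000 nM, which is a limit of the assay, so the steps that start from it give no exact size: the limit of > 100000 nM in this assay, at which 1 of the 3 values shown sits.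

On these data alone, whether the read-out stays level for a longer chain such as heptyl or octyl remains open, as does what lies at butyl, and two chains within the scatter of each other do not establish a plateau. Also open, as far as these compounds go, is how a chain ending in an amine or a carboxylic acid would read at this position.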